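Swapping an aryl for an amide-linked aryl on the triazole

A few compounds are considered here, and "the series" means these few. Any claim that something is new, unique, unknown or untested is made for them only; others in the source may bear on it.

Compound 1 `CCOC(=O)C1=Cc2ccccc2OC1(OCc1cn(CC(=O)NC2CCCCC2)nn1)C(F)(F)F`: 10200 nM
Compound 2 `CCOC(=O)C1=Cc2ccccc2OC1(OCc1cn(-c2ccccc2)nn1)C(F)(F)F`: > 150000 nM
Compound 3 `CCOC(=O)C1=Cc2ccccc2OC1(OCc1cn(-c2ccc(F)c(Cl)c2)nn1)C(F)(F)F`: 21500 nM

Three compounds share a core and differ only in the group on an aromatic nitrogen. In a functional assay on DU-145 cells (Homo sapiens) for inhibition, read by MTT assay, with a stated time of 24 h (a higher number here means a weaker inhibitor, a lower number a stronger inhibitor), compound 1 gives 10200 nM. Compound 2 reaches only the limit (the limit of > 150000 nM in this assay, at which 1 of the 3 values shown sits), so no number is known for it. Compound 3 gives 21500 nM, the highest of the two numbers shown; the steps of a 2.1-fold higher number from compound 1 to compound 3 (0.32 log units; beyond the scatter) and an at least 6.9-fold lower number from compound 2 to compound 3 (0.84 log units; beyond the scatter) frame it. Compound 4 `CCOC(=O)C1=Cc2ccccc2OC1(OCc1cn(CC(=O)Nc2cccc(F)c2)nn1)C(F)(F)F` carries ((3-fluorophenyl)carbamoyl)methyl in place of 3-chloro-4-fluorophenyl on an aromatic nitrogen, which brings back the carbamoylmethyl linker of compound 1. The step of a 2.1-fold higher number from compound 1 to compound 3 (0.32 log units; beyond the scatter), read in reverse, therefore bears on it most directly, and a modest lowering is expected for compound 4, as a 1.8-fold lower number from compound 3 to compound 4 (0.25 log units; within the scatter). Compound 4 is estimated at 12000 nM, between 5000 nM and 30000 nM.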

Compound 4, half-maximal inhibitory concentration: > 150000 nM
Compound 4 was reported as a limit (the forecaster's own chance of this, stated with the estimate: 10%); middle value at least 12-fold (1.09 log units) away from the limit.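

With the carbamoylmethyl linker kept, 3-fluorophenyl in place of cyclohexyl on the amide-type nitrogen gives an at least 14-fold higher number from compound 1 to compound 4 (1.16 log units; beyond the scatter) in this assay, so the linker alone does not secure activity and the group at its far end counts heavily. Compound 4 also falls short of the directly attached aryl of compound 3, with an at least 6.9-fold higher number from compound 3 to compound 4 (0.84 log units; beyond the scatter). Neither compound 2 nor compound 4 gives a number, so the step between them cannot be read: the limit of > 150000 nM in this assay, at which 2 of the 4 values shown sit.

Still open, going by these compounds, is whether only cyclohexyl works on that amide-type nitrogen, or whether a cyclopentyl or butyl group would serve as well.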